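The source may report more compounds than this note shows. Statements on the series, on what has been measured and on what is new or still open speak of the compounds shown alone.

For the measured compounds named here, compound 1 `O=C(NCc1ccc(S(=O)(=O)c2cc(F)cc(F)c2)cc1)N1Cc2ccncc2C1` gives 6.3 nM in a functional assay on A2780 cells (Homo sapiens) for cytotoxicity, read by sulforhodamine B assay, with a stated time of 72 h (a lower number here means a stronger inhibitor, a higher number a weaker inhibitor), the lowest of the three numbers measured so far. Compound 2 `CC(=O)N1CCC(S(=O)(=O)c2ccc(CNC(=O)N3Cc4ccncc4C3)cc2)CC1` gives 110 nM, and compound 3 `O=C(NCc1ccc(S(=O)(=O)N2CCOCC2)cc1)N1Cc2ccncc2C1` gives 68 nM; between them, a 1.6-fold lower number from compound 2 to compound 3 (0.21 log units; within the scatter). Compound 4 `O=C(NCc1ccc(S(=O)(=O)N2CCC[C@H](O)C2)cc1)N1Cc2ccncc2C1` differs from compound 1 in one place: 3-hydroxypiperidin-1-yl in place of 3,5-difluorophenyl on a sulfonyl sulfur. Going by the values given here, two measured steps bear on this change, both exchanging the same 3,5-difluorophenyl on the sulfonyl sulfur for a six-membered non-aromatic ring: a 17-fold higher number from compound 1 to compound 2 (1.24 log units; beyond the scatter) and an 11-fold higher number from compound 1 to compound 3 (1.03 log units; beyond the scatter). The entering 3-hydroxypiperidin-1-yl resembles morpholin-4-yl as a six-membered non-aromatic ring, so a large step toward a higher number in this assay is expected. Compound 4 is therefore estimated at 80 nM, between 30 nM and 250 nM. This estimate means a 13-fold higher number from compound 1 to compound 4 (1.10 log units; beyond the scatter).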

Compound 4, half-maximal inhibitory concentration: 150 nM
The estimate for compound 4 lay 1.9-fold (0.27 log units) below the measured number, and the stated range covers the measured number.
By their numbers in this assay, from the lowest: compound 1; then compounds 3, 2 and 4 (each within the scatter of the next, the first and the last beyond it).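

The step away from 3,5-difluorophenyl now holds for a third non-aromatic ring on the sulfonyl sulfur, this one carrying a hydrogen-bond donor: a 24-fold higher number from compound 1 to compound 4 (1.38 log units; beyond the scatter). Among the non-aromatic groups, the position still separates some replacements, with a 2.2-fold higher number from compound 3 to compound 4 (0.34 log units; beyond the scatter), a modest step, whereas a 1.4-fold higher number from compound 2 to compound 4 (0.13 log units; within the scatter) stays within the scatter. Nothing available explains these differences.

On these data alone, whether another aromatic ring, such as unsubstituted phenyl or pyridine, would stay close to compound 1 remains open. So does the effect of a piperazine or of the other stereoisomer of the 3-hydroxypiperidin-1-yl group.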